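Methyl to tert-butyl: compound 3 to compound 4

The source may hold more compounds than are shown below. What is called first, only, known or untested is meant among the compounds shown, and "the series" means these compounds.

In a functional assay on SMMC-7721 cells (Homo sapiens) for inhibition, read by CCK-8 assay, with a stated time of 72 h, tested at 2 uM (a lower number here means less inhibition of growth, a higher number more inhibition of growth at the concentration tested), compound 3 `Cc1ccc(SCc2ccc(/C=C/C(=O)Nc3ccccc3N)cc2)cc1` gives 22% and lies within the scatter of compound 2 `CCc1ccc(SCc2ccc(C(=O)Nc3ccccc3N)cc2)cc1` at 25.7%. Compound 1 `Cc1cc(C)cc(SCc2ccc(/C=C/C(=O)Nc3ccccc3N)cc2)c1` gives 8.61% in the same read-out. Compound 4 `CC(C)(C)c1ccc(SCc2ccc(/C=C/C(=O)Nc3ccccc3N)cc2)cc1` differs from compound 3 by tert-butyl in place of methyl on an aromatic carbon with tert-butyl in place of methyl on an aromatic carbon, para to a large group. Within the data shown here, one measured step bears on this change, the modest a number 13.4 percentage points higher from compound 1 to compound 3 (beyond the scatter) for 4-methylphenyl in place of 3,5-dimethylphenyl on a sulfur, and this step lies beyond the scatter. Among the measured compounds shown here, no measured compound carries tert-butyl, so no step beyond the scatter is expected and the direction stays open. The estimated step is a number 4 percentage points lower from compound 3 to compound 4 (within the scatter) in this assay and lies within the scatter. For compound 4 the estimated value is 18% with an expected range from 5% to 34% in this read-out.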

Compound 4, percent growth inhibition at one concentration: 18.3%
Compound 4: the middle estimate sits 0.3 percentage points below what was measured, and the stated range covers the measured number.
By their numbers in this assay, from the lowest: compounds 1, 4, 3 and 2 (each within the scatter of the next, the first and the last beyond it).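

In this assay the aromatic carbon para to a large group accepts tert-butyl in place of methyl with a number 3.7 percentage points lower from compound 3 to compound 4 (within the scatter) and so shows no readable change from the larger group. Replacing 3,5-dimethylphenyl on a sulfur with 4-(tert-butyl)phenyl gives a number 9.7 percentage points higher from compound 1 to compound 4 (within the scatter) and, unlike the step to 4-methylphenyl, this step does not pass beyond the scatter. No available evidence gives a cause for either step.

Going by these compounds, whether an amine, a carboxylic acid or a methoxy group at this position would separate from methyl remains open. On these data alone, the shape of any concentration response for these compounds also remains open.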